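Chloro to Nitro: Expected Cytotoxicity of Compound 4

A few compounds are considered here, and "the series" means these few. Any claim that something is new, unique, unknown or untested is made for them only; others in the source may bear on it.

Measured compounds in an ADME assay on L132 cells (Homo sapiens) for cytotoxicity, read by MTT assay, with a stated time of 48 h; on this read-out lower numbers stand for stronger inhibition and higher numbers for weaker inhibition:
Compound 1, `C/C(=C\CC/C(C)=C/CC[C@@H]1[C@@]2(C)CCC(=O)C(C)(C)[C@H]2CC[C@@]1(C)O)CC/C=C(\C)C(=O)OCc1cn(-c2ccccc2Cl)nn1`, gives > 150000 nM, which is a limit of the assay.
Compound 2, `C/C(=C\CC/C(C)=C/CC[C@@H]1[C@@]2(C)CCC(=O)C(C)(C)[C@H]2CC[C@@]1(C)O)CC/C=C(\C)C(=O)OCc1cn(-c2ccccc2C)nn1`, gives > 150000 nM, also a limit.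
Compound 3, `C/C(=C\CC/C(C)=C/CC[C@@H]1[C@@]2(C)CCC(=O)C(C)(C)[C@H]2CC[C@@]1(C)O)CC/C=C(\C)C(=O)OCc1cn(-c2ccccc2C(F)(F)F)nn1`, gives > 150000 nM, again a limit.

Compound 1 therefore stands only at a limit, not at a number, and the same holds for the other two compounds, as summarised by the limit of > 150000 nM in this assay, at which 3 of the 3 values shown sit. Compound 4, `C/C(=C\CC/C(C)=C/CC[C@@H]1[C@@]2(C)CCC(=O)C(C)(C)[C@H]2CC[C@@]1(C)O)CC/C=C(\C)C(=O)OCc1cn(-c2ccccc2[N+](=O)[O-])nn1`, differs from compound 1 by nitro in place of chloro on an aromatic carbon. The measured steps that bear on this change are the two that start from compound 1 and exchange the same chloro for another group: a step that the two limits leave unreadable from compound 1 to compound 2 and a step that the two limits leave unreadable from compound 1 to compound 3. The third, a step that the two limits leave unreadable from compound 2 to compound 3, is equally unreadable. None of these steps gives a size or a direction, so no step beyond the scatter can be foreseen in this assay for the change to nitro. Compound 4 is accordingly expected to give 200000 nM, within 60000 nM to 600000 nM, most likely reported again as a limit; the expected step is a step that the limit leaves unreadable from compound 1 to compound 4.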

Compound 4, half-maximal inhibitory concentration: > 150000 nM
Compound 4: only a limit was reported; the forecaster's own chance of this, stated with the estimate: 80%; the middle value lies beyond the limit too.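

Compound 4 also stands only at a limit, like compound 1, compound 2 and compound 3, so no step among these compounds can be read: the limit of > 150000 nM in this assay, at which 4 of the 4 values shown sit.

The compounds shown leave open whether the chloro, methyl, trifluoromethyl and nitro compounds differ at all, and how they would rank.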